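From oxolan-3-yl to cyclopropyl on a shared core

The compounds below may be only part of what the source reports. "The series", "measured", "known", "first", "only" and "open" are said of these compounds alone.

Going by the values given here, in a physicochemical assay for solubility, using the shake flask method, in simulated intestinal fluid, measured as kinetic solubility, with a stated time of 20 h, at pH 6.5 (a lower number here means a less soluble compound, a higher number a more soluble compound), compound 3 (`FC(F)(F)c1ccc(Nc2cc3[nH]c(C4CCOC4)nc3cn2)nc1`) gives 180000 nM as the only actual number among the three compounds measured. Compound 1 (`FC(F)(F)c1ccc(Nc2cc3[nH]c(-c4cccc(C(F)(F)F)c4)nc3cn2)nc1`) stands at >= 50000 nM as a limit and not a number. Compound 2 (`Fc1ccc(-c2nc3cnc(Nc4ccc(C(F)(F)F)cn4)cc3[nH]2)cc1F`) stands at >= 50000 nM as a limit too. Compound 3 therefore cannot be ranked against either of them.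

Compound 4 (`FC(F)(F)c1ccc(Nc2cc3[nH]c(C4CC4)nc3cn2)nc1`) differs from compound 3 in one place (cyclopropyl in place of oxolan-3-yl on an aromatic carbon): cyclopropyl in place of oxolan-3-yl on an aromatic carbon. Among the compounds with values here, two measured steps touch that same place (a step that the limit leaves unreadable from compound 1 to compound 3) and (a step that the limit leaves unreadable from compound 2 to compound 3), but neither yields a size, and neither involves cyclopropyl. The remaining step (a step that the two limits leave unreadable from compound 1 to compound 2) adds no size either. The data thus fix no magnitude for this change, and the expectation has a single anchor, compound 3 at 180000 nM as its starting point, so it stays broad. Within the data shown here, the expected change is a 2.6-fold lower number from compound 3 to compound 4 (0.41 log units; beyond the scatter) as a moderate fall, though that direction is an estimate and no measured step confirms it. Compound 4 is estimated in this assay at 70000 nM with an expected range from 20000 nM to 180000 nM and may turn out to be only a limit.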

Compound 4, solubility: 123000 nM
Beside the measured number, compound 4's estimate is 1.8-fold (0.24 log units) below it; the range from low to high includes it.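

In this assay, the place between two ring nitrogen atoms now has its first readable step, a 1.5-fold lower number from compound 3 to compound 4 (0.17 log units; within the scatter) on the shared core, where cyclopropyl replaces oxolan-3-yl. The earlier compounds shown here gave no size at this place, and this one pair shows that a ring with 1 hydrogen-bond acceptor can give way to an all-carbon ring with none, and to fewer heavy atoms, without a change beyond the scatter. The steps from compound 1 and from compound 2 to compound 4 still cannot be read, because those two compounds carry a limit and not a number: the limit of >= 50000 nM in this assay, at which 2 of the 4 values shown sit.

What the compounds shown leave open is whether any group at this place moves the number beyond the scatter, since a single readable step gives no trend; a primary amine or a carboxylic acid on the same carbon would test that. On these data alone, it also stays open whether the step from oxolan-3-yl to cyclopropyl would keep its size on a core other than the shared one, or with another group in place of the trifluoromethyl on the pyridine-bearing side of the shared core.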